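Aryl replacement on the ethylamine-linked series, antiproliferative read-out

This account rests on a few compounds, and the source may have more. Where it says the series, first, only, none or still open, it means among the compounds named here.

Measured so far:
compound 1 `N#Cc1ccc(N2CCCc3c(-c4cccnc4)cccc32)cc1C(F)(F)F` — 13500 nM
compound 2 `CCN(c1ccc(C#N)c(Cl)c1)c1cc(-c2ccccc2)ccc1C` — > 30000 nM
compound 3 `CCN(c1ccc(C#N)c(C(F)(F)F)c1)c1cc(-n2ccnc2)ccc1C` — >= 3920 nM

In a functional assay on VCaP cells (Homo sapiens) for antiproliferative activity, read by CCK-8 assay, with a stated time of 6 days (on this read-out higher numbers stand for weaker inhibition and lower numbers for stronger inhibition), compound 1 gives 13500 nM. Compound 2 gives only a limit of this assay, > 30000 nM (the limit of > 30000 nM in this assay, at which 1 of the 3 values shown sits). Compound 3 likewise gives only a limit, >= 3920 nM (the limit of >= 3920 nM in this assay, at which 1 of the 3 values shown sits). Within the data shown here, compound 2 thus sits at the upper limit of this assay, with no number of its own; no step between the three measured compounds is given, so their values can only be set side by side.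

Compound 4 `CCN(c1ccc(C#N)c(Cl)c1)c1cc(-c2c[nH]nc2C)ccc1C` differs from compound 2 in one place: 3-methyl-1H-pyrazol-4-yl in place of phenyl on an aromatic carbon. Among the measured compounds shown here, no measured step covers this change. The expected step is an at least 3.0-fold lower number from compound 2 to compound 4 (0.47 log units; beyond the scatter), a gain in inhibition beyond the scatter. Compound 4 is estimated at 10000 nM in this assay, within 2500 nM to 30000 nM.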

Compound 4, half-maximal inhibitory concentration: 3190 nM
Beside the measured number, compound 4's estimate is 3.1-fold (0.50 log units) above it; the measured number falls inside the stated range.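

On the aromatic carbon meta to a large group and para to a methyl group, 3-methyl-1H-pyrazol-4-yl in place of phenyl gives a gain in inhibition in this assay (an at least 9.4-fold lower number from compound 2 to compound 4 (0.97 log units; beyond the scatter)). Among these compounds, this is the first readable step, and it shows that this carbon can carry a five-membered aromatic ring with 2 hetero atoms. The step has only a lower bound because compound 2 stands at a limit: the limit of > 30000 nM in this assay, at which 1 of the 4 values shown sits.

The shown compounds do not separate the methyl group from the ring nitrogens. Unsubstituted 1H-pyrazol-4-yl, or phenyl bearing an amine, would address this.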